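A few compounds are considered here, and "the series" means these few. Any claim that something is new, unique, unknown or untested is made for them only; others in the source may bear on it.

Measured in an ADME assay on HEp-2 cells (Homo sapiens) for cytotoxicity, read by MTT assay, with a stated time of 24 h; a higher number here means that more compound is tolerated, a lower number that less compound is tolerated:
- Compound 1 `CCC(=O)OCCc1ccc(O)c(O)c1`: 40 ug/mL
- Compound 2 `CCCC(=O)OCCc1ccc(O)c(O)c1`: 100 ug/mL

Of these two numbers, compound 2 holds the higher at 100 ug/mL, so more of it is tolerated. Among the compounds with values here, the only measured step is a 2.5-fold higher number from compound 1 to compound 2 (0.40 log units; beyond the scatter), which is modest but beyond the scatter. Compound 3 `CCCCC(=O)OCCc1ccc(O)c(O)c1` makes the same kind of change once more: methyl in place of hydrogen on a saturated chain carbon, three bonds along the chain from a carbonyl carbon. This places methyl in place of hydrogen on a saturated chain carbon, three bonds along the chain from a carbonyl carbon, taking propyl to butyl. Because of a 2.5-fold higher number from compound 1 to compound 2 (0.40 log units; beyond the scatter) a further modest rise in this assay is expected, although a single step cannot establish a trend and the direction remains uncertain. The expected change is a 1.8-fold higher number from compound 2 to compound 3 (0.26 log units; within the scatter). Compound 3 is estimated at 180 ug/mL, with an expected range from 80 ug/mL to 400 ug/mL.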

Compound 3, half-maximal cytotoxic concentration: 25 ug/mL
Compound 3: the middle estimate sits 7.2-fold (0.86 log units) above what was measured; the measured number lies below the stated range.
By their numbers in this assay, from the lowest: compounds 3 and 1 (each within the scatter of the next); then compound 2.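

In this assay, adding one more carbon to the chain does not repeat the earlier rise: methyl in place of hydrogen on a saturated chain carbon, three bonds along the chain from a carbonyl carbon, gives a 4.0-fold lower number from compound 2 to compound 3 (0.60 log units; beyond the scatter) and reverses the direction of a 2.5-fold higher number from compound 1 to compound 2 (0.40 log units; beyond the scatter) on going from propyl to butyl. Compound 3 does not fall clearly away from the shortest chain in the set, since the comparison shows a 1.6-fold lower number from compound 1 to compound 3 (0.20 log units; within the scatter) and so leaves compounds 1 and 3 level, with compound 2 alone standing higher. Nothing available explains why tolerance changes this way along the chain.

From the compounds shown here alone, whether a longer chain such as hexyl would stay level with compound 3 or move further remains open. So does the effect of ending the chain in an amine or a carboxylic acid.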